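The source may report more compounds than this note shows. Statements on the series, on what has been measured and on what is new or still open speak of the compounds shown alone.

Measured compounds:
Compound 1 `COc1ccc(Cn2c(CCc3ccccc3)nnc2[C@H](NC(=O)c2ccncc2)c2c[nH]c3ccccc23)cc1` gives in a functional assay on CHO cells for antagonist activity at growth hormone secretagogue receptor type 1 (Homo sapiens); a higher number here means a weaker inhibitor, a lower number a stronger inhibitor "not determined" (no result reported).
Compound 2 `COc1ccc(Cn2c(CCc3c[nH]c4ccccc34)nnc2[C@H](NC(=O)Cc2ccncc2)c2c[nH]c3ccccc23)cc1` gives in this assay 10 nM.
Compound 3 `COc1ccc(Cn2c(CCc3ccccc3)nnc2[C@H](NC(=O)Cc2ccncc2)c2c[nH]c3ccccc23)cc1` gives in this assay "not determined" (no result reported).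

Compound 3 stands without a number of its own in this assay; compound 1 likewise has none, so the only figure in this set belongs to compound 2, and compound 2 is not a single-change neighbour of compound 3, so no step can be read from it. Compound 4 `COc1ccc(Cn2c(CCc3ccccc3)nnc2[C@H](NC(=O)c2cnccn2)c2c[nH]c3ccccc23)cc1` differs from compound 3 in one place: pyrazin-2-yl in place of (pyridin-4-yl)methyl on a carbonyl carbon. Among the measured compounds shown here, with no measured step available for this change and no value for compound 3 itself, the direction and size of the step cannot be anchored; the expectation rests only on the fact that a close analogue, compound 2, reaches 10 nM in this assay. Compound 4 is therefore expected to give about 40 nM in this assay, within a broad range from 5 nM to 400 nM.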

Compound 4, antagonist equilibrium constant: 530 nM
Beside the measured number, compound 4's estimate is 13-fold (1.12 log units) below it; the measured number lies above the stated range.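

In this assay, among the compounds shown here, compound 4 gives 530 nM, but no step from compound 3 to compound 4 can be read from this result. No evidence at hand bears on the value. The compounds shown leave open what replacing (pyridin-4-yl)methyl with pyrazin-2-yl does on its own.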